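Extending the hydroxycarbamoyl chain past two assay limits

The compounds below may be only part of what the source reports. "The series", "measured", "known", "first", "only" and "open" are said of these compounds alone.

In a functional assay on CNE-2 cells (Homo sapiens) for inhibition, read by MTT assay, with a stated time of 72 h (on this read-out lower numbers stand for stronger inhibition and higher numbers for weaker inhibition), compound 1 (`Nc1ncnc2c1c(-c1cnc3[nH]ccc3c1)nn2CCCCC(=O)NO`) gives > 150000 nM as a limit of the assay. In this assay compound 2 (`Nc1ncnc2c1c(-c1cnc3[nH]ccc3c1)nn2CCCCCC(=O)NO`) stands at > 50000 nM and this too is a limit, not a number. The change to compound 3 (`Nc1ncnc2c1c(-c1cnc3[nH]ccc3c1)nn2CCCCCCCCCC(=O)NO`) is this (4-(hydroxycarbamoyl)butyl in place of hydroxycarbamoyl on a saturated chain carbon, five bonds along the chain from an aromatic nitrogen): 4-(hydroxycarbamoyl)butyl in place of hydroxycarbamoyl on a saturated chain carbon, five bonds along the chain from an aromatic nitrogen. Going by the values given here, the one measured step that bears on it is a step that the two limits leave unreadable from compound 1 to compound 2 and so it offers no size or direction to carry forward. The expected direction, resting only on the much longer chain, is towards stronger inhibition, and the estimated step is an at least 1.6-fold lower number from compound 2 to compound 3 (0.22 log units; that floor lies within the scatter) as a loose expectation. For compound 3 the estimated value is 30000 nM with 5000 nM to 150000 nM as the expected span.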

Compound 3, half-maximal inhibitory concentration: 2200 nM
Beside the measured number, compound 3's estimate is 14-fold (1.13 log units) above it; the measured number lies below the stated range.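

Setting 4-(hydroxycarbamoyl)butyl in place of hydroxycarbamoyl at this position gives the first readable steps in this assay, an at least 22-fold lower number from compound 2 to compound 3 (1.35 log units; beyond the scatter) and an at least 68-fold lower number from compound 1 to compound 3 (1.83 log units; beyond the scatter), whereas the earlier pair offered neither size nor direction. The step from compound 1 is only a floor because compound 1 stands at a limit of the assay, not at a number: the limit of > 150000 nM in this assay, at which 1 of the 3 values shown sits. Likewise, the step from compound 2 is only a floor because compound 2 stands at a limit of the assay: the limit of > 50000 nM in this assay, at which 1 of the 3 values shown sits.

The compounds shown leave open whether the change in this assay sets in gradually at chain lengths between those of compound 2 and compound 3, and whether a still longer chain would go further. They also leave open whether a carboxylic acid at the chain end could stand in for the hydroxycarbamoyl group.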